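A Shorter Chain Between Two Amides

The compounds below may be only part of what the source reports. "The series", "measured", "known", "first", "only" and "open" are said of these compounds alone.

Compound 1, `CN(C)C(=O)CCNC(=O)C1CSC(c2ccc(F)cc2)N1`: 32%
Compound 2, `CC(CNC(=O)c1cc(-c2ccc(F)cc2)no1)C(=O)N(C)C`: 52%

Both compounds were tested in an ADME assay on microsomes from liver (Macaca mulatta) for metabolic stability, with a stated time of 0.5 h, tested at 0.5 mg/mL; on this read-out higher numbers stand for a more stable compound and lower numbers for a less stable compound. Among the measured compounds shown here, compound 2 stands highest of the two numbers; its only neighbour, compound 1, lies a step lower that goes beyond the usual scatter of this kind of measurement. Compound 3, `CN(C)C(=O)CNC(=O)c1cc(-c2ccc(F)cc2)no1`, has not yet been measured. It differs from compound 2 in a single place: dimethylcarbamoyl in place of 1-(dimethylcarbamoyl)ethyl on a saturated chain carbon bound to an amide-type nitrogen. For the measured compounds named here, no measured pair differs in just one place, so no measured step shows what such a change does here. With only the two numbers above as a guide, the expected step in this assay is a number 2 percentage points higher from compound 2 to compound 3 (within the scatter), a change no larger than the usual scatter, in no firm direction. Compound 3 is therefore estimated at 54% in this assay, with a likely range from 35% to 73%.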

Compound 3, percent of the compound remaining: 11%
Compound 3: middle estimate off by 43 percentage points, on the high side; the measured number lies below the stated range.
By their numbers in this assay, from the lowest: compound 3; then compound 1; then compound 2.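

Among the compounds shown here, compound 2 and compound 3 form the first measured pair that differs in one place, so the effect of this change can now be read directly. Putting dimethylcarbamoyl in place of 1-(dimethylcarbamoyl)ethyl on a saturated chain carbon bound to an amide-type nitrogen gives a number 41 percentage points lower from compound 2 to compound 3 (beyond the scatter) in this assay, so this position is far from indifferent to what sits there, even though the group that leaves has 7 heavy atoms and the group that enters has 5. Nothing measured here gives a reason for this step.

As far as these compounds go, it remains open whether a longer chain or a carboxylic acid at this place would keep the compound as stable as compound 2 or lower the number further. Also open, from the compounds shown here alone, is whether the same change would have a similar effect on the core of compound 1.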